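This account rests on a few compounds, and the source may have more. Where it says the series, first, only, none or still open, it means among the compounds named here.

In a physicochemical assay for solubility, in phosphate buffer, at pH 7.4 (on this read-out higher numbers stand for higher solubility and lower numbers for lower solubility), compound 1 `OCCC1CCN(c2nccnc2OC2CN(c3ccc4ccccc4n3)C2)CC1` gives 84000 nM, the highest of the three numbers recorded so far. Compound 2 `N#CC1CCN(c2nccnc2OC2CN(c3ccc4ccccc4n3)C2)CC1` gives 66000 nM, and the step of a 1.3-fold lower number from compound 1 to compound 2 (0.10 log units; within the scatter) falls within the scatter, so these two compounds cannot be placed in order. Compound 3 `NC(=O)C1CCN(c2nccnc2OC2CN(c3ccc4ccccc4n3)C2)CC1` gives 14000 nM; here the steps of a 6.0-fold lower number from compound 1 to compound 3 (0.78 log units; beyond the scatter) and a 4.7-fold lower number from compound 2 to compound 3 (0.67 log units; beyond the scatter) both lie beyond the scatter.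

Compound 4 `OCc1cccc(-c2nccnc2OC2CN(c3ccc4ccccc4n3)C2)c1` has not yet been measured in this assay. It differs from compound 1 in one place: 3-(hydroxymethyl)phenyl in place of 4-(2-hydroxyethyl)piperidin-1-yl on an aromatic carbon. Among the measured compounds shown here, every measured step so far exchanges only the group attached to a saturated ring carbon inside the 4-(2-hydroxyethyl)piperidin-1-yl group, leaving that ring itself in place. Those steps show that such an exchange can shift the number by as much as a 6.0-fold lower number from compound 1 to compound 3 (0.78 log units; beyond the scatter) or leave it unchanged, as in a 1.3-fold lower number from compound 1 to compound 2 (0.10 log units; within the scatter). For the measured compounds named here, no measured step replaces the whole saturated ring with an aromatic one, so nothing recorded bears directly on this change, and the expectation is correspondingly uncertain. A lowering is expected, a 4.2-fold lower number from compound 1 to compound 4 (0.62 log units; beyond the scatter), with a broad range. Compound 4 is therefore estimated at 20000 nM, expected to fall between 4000 nM and 80000 nM.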

Compound 4, solubility: 29000 nM
Compound 4: the middle estimate sits 1.5-fold (0.16 log units) below what was measured; measured number inside the range.
By their numbers in this assay, from the lowest: compound 3; then compound 4; then compounds 2 and 1 (each within the scatter of the next).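

Replacing the whole six-membered non-aromatic ring with a six-membered aromatic ring of carbon only, on the aromatic carbon next to the ring nitrogen, is still compatible with a fairly high number in this assay: the results are a 2.9-fold lower number from compound 1 to compound 4 (0.46 log units; beyond the scatter) and a 2.3-fold lower number from compound 2 to compound 4 (0.36 log units; beyond the scatter). Compared with the 4-carbamoylpiperidin-1-yl group, the same kind of replacement goes the other way, a 2.1-fold higher number from compound 3 to compound 4 (0.32 log units; beyond the scatter), so whether 3-(hydroxymethyl)phenyl comes out lower or higher depends on which saturated group it replaces. No measurement here explains these differences, and the aromatic ring, the loss of the ring nitrogen and the shorter hydroxymethyl chain all arrive together in this one change.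

As far as these compounds go, it remains open how much of the difference belongs to the ring and how much to the chain, a question that a phenyl group carrying a 2-hydroxyethyl chain would help to separate. From the compounds shown here alone, it also remains open how the read-out would respond if the hydroxymethyl group on the phenyl ring gave way to an aminomethyl group or a carboxylic acid.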